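The compounds below may be only part of what the source reports. "The series", "measured", "known", "first", "only" and "open" are said of these compounds alone.

Compound 1 `O=C(O)CN1C(=O)/C(=C/c2nc3ccccc3n2Cc2ccc(F)cc2)SC1=S` and compound 2 `O=C(O)CN1C(=O)/C(=C/c2nc3ccccc3n2Cc2ccc(Cl)cc2)SC1=S` share a core and differ in a single halogen on the benzyl ring. In a functional assay on PC-3 cells (Homo sapiens) for cytotoxicity, read by MTT assay, with a stated time of 48 h (on this read-out higher numbers stand for weaker inhibition and lower numbers for stronger inhibition), compound 1 gives 4860 nM, and compound 2 gives 9670 nM. The change between them is fluoro in place of chloro on an aromatic carbon and it produced a 2.0-fold lower number from compound 2 to compound 1 (0.30 log units; within the scatter). Compound 3 `Cc1ccc(Cn2c(/C=C3\SC(=S)N(CC(=O)O)C3=O)nc3cc(Cl)ccc32)cc1` is built on a different core; the difference between the two cores is not broken down here. In this assay compound 3 gives 26700 nM, the highest of the three numbers and beyond the scatter from both others. Compound 4 `Cc1ccc(Cn2c(/C=C3\SC(=S)N(CC(=O)O)C3=O)nc3cc(F)ccc32)cc1` has not yet been measured; it differs from compound 3 by fluoro in place of chloro on an aromatic carbon. Among the measured compounds shown here, this is the same kind of change as the one from compound 2 to compound 1, but at a different place: in the earlier pair the carbon sits on a six-membered aromatic ring of carbon only, para to a large group, whereas here it is part of a fused or bridged system of two rings, meta to a fused ring and para to a fused ring. Because a 2.0-fold lower number from compound 2 to compound 1 (0.30 log units; within the scatter) stayed within the scatter, only a small shift is anticipated. For compound 4 the expected step is a 1.5-fold lower number from compound 3 to compound 4 (0.17 log units; within the scatter). Compound 4 is therefore estimated at 18000 nM, with a likely range from 8000 nM to 45000 nM.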

Compound 4, half-maximal inhibitory concentration: 10200 nM
Compound 4: the middle estimate sits 1.8-fold (0.25 log units) above what was measured, and the stated range covers the measured number.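

In this assay, fluoro in place of chloro on an aromatic carbon gives a 2.6-fold lower number from compound 3 to compound 4 (0.42 log units; beyond the scatter). Set beside the earlier pair, this step cannot be told apart in size from the one on the other core: the same change on two cores in this assay, a 2.0-fold lower number (0.30 log units; within the scatter) from compound 2 to compound 1 and a 2.6-fold lower number (0.42 log units; beyond the scatter) from compound 3 to compound 4, 1.3-fold (0.12 log units) apart, within the scatter of two such steps. This shows that, for these two pairs, the change carries from the core of compound 1 to the core of compound 3 without a detectable difference in its size, but it does not establish a rule for other cores, and since the carbon carrying the halogen also lies in a different place in the two pairs, the data cannot separate an effect of the core from an effect of that place.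

As far as these compounds go, what a bromo, a methoxy or a nitrile on the same aromatic carbon would give remains open. Also open, from the compounds shown here alone, is whether the step would hold if the carboxylic acid were exchanged for an amide or carried on a longer chain.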